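The compounds below may be only part of what the source reports. "The series", "measured", "known", "first", "only" and "open" are said of these compounds alone.

Two compounds built on one shared core have been run through an ADME assay on S9 fraction from liver (Rattus norvegicus) for metabolic stability, read by LC-MS, using NADPH, with a stated time of 30 min; on this read-out higher numbers stand for a more stable compound and lower numbers for a less stable compound. Compound 1 `CC(Oc1ccc(Oc2ccc(C(F)(F)F)cc2)cc1)C(=O)Cn1nnc(-c2ccccc2)n1` carries a trifluoromethyl group on one of its outer rings, and in this assay compound 1 gives 6%. Compound 2 `CC(Oc1ccc(Oc2ccc(F)cc2)cc1)C(=O)Cn1nnc(-c2ccc(Cl)cc2)n1` carries fluoro at that place and chloro on the ring at the far end of the molecule. For compound 2 this assay reports only a limit, < 5%, and not a number. Compound 2 therefore stands at the floor of this assay, as described by the limit of < 5% in this assay, at which 1 of the 2 values shown sits, and both measured values sit low.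

Compound 3 `CC(Oc1ccc(Oc2ccc(C(F)(F)F)cc2)cc1)C(=O)Cn1nnc(-c2ccc(Cl)cc2)n1` is the unmeasured compound. It differs from compound 2 in a single place: trifluoromethyl in place of fluoro on an aromatic carbon. Compound 1 also carries trifluoromethyl on that ring and gives 6%, so both ends of the comparison point to low stability. The expected step of a number at least 1 percentage points higher from compound 2 to compound 3 (that floor lies within the scatter) is none beyond the scatter. Compound 3 is expected to give about 6% in this assay, with a range from 2% to 14%.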

Compound 3, percent of the compound remaining: 9%
Compound 3: middle estimate off by 3 percentage points, on the low side, and the stated range covers the measured number.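

This first one-place comparison at the outer ring shows that, in this assay, trifluoromethyl in place of fluoro, para to a large group, gives a number at least 4 percentage points higher from compound 2 to compound 3 (that floor lies within the scatter), so this change moves the compound by no more than the usual scatter can account for. Compound 2 is known only through a limit of the assay, so the real size of this step stays open: the limit of < 5% in this assay, at which 1 of the 3 values shown sits.

The second comparison adds a reading at the ring at the far end of the molecule, where chloro in place of hydrogen gives a number 3 percentage points higher from compound 1 to compound 3 (within the scatter), and this step also cannot be told apart from the scatter.

Neither change shown, at either ring, lifts the compound clear of the low end of this read-out, and three compounds on one shared core cannot say which part of the molecule is lost in the assay. As far as these compounds go, whether a different kind of group at the place of the trifluoromethyl, such as an amine, a carboxylic acid or a longer chain, would give a clearly more stable compound remains open.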